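The source may report more compounds than this note shows. Statements on the series, on what has been measured and on what is new or still open speak of the compounds shown alone.

In a functional assay on THP-1 cells (Homo sapiens) for inhibition, read by sulforhodamine B assay, with a stated time of 48 h, tested at 50 uM (a lower number here means less inhibition of growth, a higher number more inhibition of growth at the concentration tested), compound 2 (`COc1ccccc1/C=C/C(=O)/C=C/c1ccc(OCc2cn(CCOc3cc(=O)oc4ccccc34)nn2)c(OC)c1`) gives 75% and compound 1 (`COc1cc(/C=C/C(=O)/C=C/c2cccs2)ccc1OCc1cn(CCOc2cc(=O)oc3ccccc23)nn1`) gives 76%, so the two stand level within the usual scatter. Compound 3 (`COc1ccc(/C=C/C(=O)/C=C/c2ccc(OCc3cn(CCOc4cc(=O)oc5ccccc45)nn3)c(OC)c2)cc1`) has not yet been measured. It differs from compound 2 in one place: 4-methoxyphenyl in place of 2-methoxyphenyl on a double-bonded chain carbon bound to a double-bonded chain carbon. For the measured compounds named here, only one measured step touches this same place, a number 1 percentage points lower from compound 1 to compound 2 (within the scatter). Going by the values given here, that step exchanged a different pair of groups, so it is indirect evidence, and no measured pair shows what shifting the methoxy group around the ring does. Still, replacing the group at this place left the number unchanged beyond the scatter in the one case available. An expected no change at the digits printed from compound 2 to compound 3 (within the scatter) therefore amounts to no change beyond the scatter. For compound 3 the estimated value is 75%, with an expected range from 63% to 86%.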

Compound 3, percent growth inhibition at one concentration: 78%
Compound 3: the middle estimate sits 3 percentage points below what was measured, within the range that was stated.
By their numbers in this assay, from the lowest: compounds 2, 1 and 3 (each within the scatter of the next).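

Moving the methoxy group, with 4-methoxyphenyl in place of 2-methoxyphenyl, keeps the same atoms and only joins them differently, and in this assay this gives a number 3 percentage points higher from compound 2 to compound 3 (within the scatter) and so does not separate the two groups. Against the sulfur-containing ring, the same group gives a number 2 percentage points higher from compound 1 to compound 3 (within the scatter) as well, so all three groups on this double-bonded chain carbon stand level, whether the change is a shift of the methoxy group or a swap of the ring. Nothing available offers an explanation for this result.

From the compounds shown here alone, all three groups hold a ring, so what a carboxylic acid, an amine or a plain alkyl chain would do at this place remains open. Readings at a single concentration also leave open whether these compounds would separate at lower concentrations.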